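A Furan for a Thiophene on the Amino-Bearing Core

The source may hold more compounds than are shown below. What is called first, only, known or untested is meant among the compounds shown, and "the series" means these compounds.

Compound 1 `COc1ncnc2c1c(-c1ccoc1)cn2[C@@H]1O[C@H](CO)[C@@H](O)[C@H]1O` carries a furan-3-yl group and no amino group on the shared core. In a functional assay on HL-60 cells (Homo sapiens) for antiproliferative activity, read by XTT assay, with a stated time of 72 h (on this read-out higher numbers stand for weaker inhibition and lower numbers for stronger inhibition), compound 1 gives 150 nM. Compound 2 `COc1nc(N)nc2c1c(-c1ccccc1)cn2[C@@H]1O[C@H](CO)[C@@H](O)[C@H]1O` has an amino group on the shared core and a phenyl group. In this assay compound 2 gives only > 20000 nM, which is a limit of the assay and not a number. Compound 3 `COc1nc(N)nc2c1c(-c1cccs1)cn2[C@@H]1O[C@H](CO)[C@@H](O)[C@H]1O` keeps that amino group and bears a thiophen-2-yl group. In this assay compound 3 also gives only > 20000 nM, again a limit rather than a number. The step that the two limits leave unreadable from compound 2 to compound 3 is therefore not readable. Compound 4 `COc1nc(N)nc2c1c(-c1ccoc1)cn2[C@@H]1O[C@H](CO)[C@@H](O)[C@H]1O` is compound 3 with furan-3-yl in place of thiophen-2-yl on an aromatic carbon. Among the compounds with values here, no measured step isolates this exchange: compound 1 also carries furan-3-yl, but it differs from compound 4 in the amino group as well, so its value cannot simply be carried over. Because the limit of > 20000 nM in this assay, at which 2 of the 3 values shown sit, holds for both compounds that carry the amino group, compound 4 is expected to sit there too, with an estimated 20000 nM and a range from 4000 nM to 80000 nM. The expected step is a number no higher from compound 3 to compound 4 (the limit leaves the size open), that is, nothing readable beyond the limit.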

Compound 4, half-maximal inhibitory concentration: > 20000 nM
Compound 4 ended at the assay's limit; the forecaster's own chance of this, stated with the estimate: 70%; the middle value lies on the limit itself.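

Compound 4 joins the furan-3-yl group of compound 1 to the amino group, so the amino group can now be read on its own: in this assay, that one change gives an at least 130-fold higher number from compound 1 to compound 4 (2.12 log units; beyond the scatter). The values of compound 2, compound 3 and compound 4 are all limits of the assay and not numbers, and the steps among them cannot be read. On the amino-bearing core, phenyl, thiophen-2-yl and furan-3-yl on this aromatic carbon all end at the same limit: the limit of > 20000 nM in this assay, at which 3 of the 4 values shown sit.

As far as these compounds go, how far past that limit these three compounds lie stays unknown, so any difference among their groups stays hidden. Also open, from the compounds shown here alone, is whether a methylamino group in place of the amino group, or a chlorine atom in place of the ring on this carbon, would give a measurable value.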